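The source may report more compounds than this note shows. Statements on the series, on what has been measured and on what is new or still open speak of the compounds shown alone.

Measured so far in a functional assay on MCF7 cells (Homo sapiens) for cytotoxicity, read by MTT assay, with a stated time of 24 h, tested at 80 ug/mL; on this read-out lower numbers stand for a weaker effect and higher numbers for a stronger effect at the one concentration tested:
compound 1 `Cn1c(-c2ccc(NC(=O)CCl)cc2)nc(-c2ccccc2)c1-c1ccccc1`: 70%
compound 2 `Cn1c(-c2ccc(NC(=O)CSc3nc4cc(Cl)ccc4o3)cc2)nc(-c2ccccc2)c1-c1ccccc1`: 69.1%
compound 3 `Cn1cnnc1SCC(=O)Nc1ccc(-c2nc(-c3ccccc3)c(-c3ccccc3)n2C)cc1`: 89.3%

Compound 3 stands highest of the three, with a number 19.3 percentage points higher from compound 1 to compound 3 (beyond the scatter) and a number 20.2 percentage points higher from compound 2 to compound 3 (beyond the scatter), while a number 0.9 percentage points lower from compound 1 to compound 2 (within the scatter). Compound 4 `Cn1c(-c2ccc(NC(=O)CSC3=NCCS3)cc2)nc(-c2ccccc2)c1-c1ccccc1` is not yet measured; it differs from compound 3 in that (a group of 5 heavy atoms (3 carbon, 1 nitrogen, 1 sulfur; one five-membered non-aromatic ring with 2 hetero atoms) in place of a group of 6 heavy atoms (3 carbon, 3 nitrogen; one five-membered aromatic ring with 3 hetero atoms), on a sulfur), the sulfur otherwise carrying a saturated chain carbon. Among the measured compounds shown here, the step bearing most directly on it is the exchange on the sulfur, a number 20.2 percentage points higher from compound 2 to compound 3 (beyond the scatter), a modest gain; the entering group has no measured counterpart, so the reader should expect a step downward in this assay of modest size, or none beyond the scatter. Compound 4 is estimated at 75%, between 60% and 92%. That estimate means an expected a number 14.3 percentage points lower from compound 3 to compound 4 (beyond the scatter).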

Compound 4, a percentage reported as activity, at one concentration (the size of the read-out at that concentration, not a potency): 70%
Compound 4: the middle estimate sits 5 percentage points above what was measured; measured number inside the range.
By their numbers in this assay, from the lowest: compounds 2, 1 and 4 (each within the scatter of the next); then compound 3.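

Placed on the sulfur in this assay, the non-aromatic ring gives a number 19.3 percentage points lower from compound 3 to compound 4 (beyond the scatter) and does not keep the higher number of the 4-methyl-4H-1,2,4-triazol-3-yl group. Against the benzoxazole group it gives a number 0.9 percentage points higher from compound 2 to compound 4 (within the scatter) and against the chloro compound no change at the digits printed from compound 1 to compound 4 (within the scatter), so among these four compounds only the 4-methyl-4H-1,2,4-triazol-3-yl group stands apart. No evidence is available to explain this. As far as these compounds go, whether an amine or a carboxylic acid on the sulfur-bound chain would reach that higher number stays open, as does whether the triazole needs its methyl.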